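Methyl on the Ring: Thiosemicarbazones in a Cell Growth Test

A few compounds are considered here, and "the series" means these few. Any claim that something is new, unique, unknown or untested is made for them only; others in the source may bear on it.

Compound 1 `Cc1ccnc(/C(N)=N/NC(=S)N2CCOCC2)c1` gives 8.16% in a functional assay on MCF7 cells (Homo sapiens) for cytotoxicity, read by MTT assay, with a stated time of 72 h, tested at 30 uM; a lower number here means less inhibition of growth, a higher number more inhibition of growth at the concentration tested.
Compound 2 `Cc1ccnc(/C(N)=N/NC(=S)N2CCSCC2)c1` gives 74.2% in this assay.
Compound 3 `N/C(=N\NC(=S)N1CCCCC1)c1ccccn1` gives 69.3% in this assay.

Among these three numbers, compound 3 stands second highest. Its value and that of compound 2 lie within the usual scatter of each other, so no order can be read between them; compound 1, by contrast, lies far lower, beyond the scatter. Among the measured compounds shown here, the only measured step that changes a single place, a number 66 percentage points higher from compound 1 to compound 2 (beyond the scatter), swaps the ring attached to the thiocarbonyl carbon, a part of the molecule that is not touched here.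

Compound 4 `Cc1ccnc(/C(N)=N/NC(=S)N2CCCCC2)c1` has not been measured. It differs from compound 3 by methyl in place of hydrogen on an aromatic carbon. For the measured compounds named here, no measured step concerns this position, so nothing in the data speaks for a shift in either direction. The expectation is therefore a step no larger than the scatter, a number 0.7 percentage points higher from compound 3 to compound 4 (within the scatter). Compound 4 is estimated at 70%, within a range from 50% to 88%.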

Compound 4, percent growth inhibition at one concentration: 61.7%
Compound 4: middle estimate off by 8.3 percentage points, on the high side, within the range that was stated.
By their numbers in this assay, from the lowest: compound 1; then compounds 4, 3 and 2 (each within the scatter of the next, the first and the last beyond it).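

In this assay, among the compounds shown here, methyl in place of hydrogen on the aromatic carbon opposite the ring nitrogen gives a number 7.6 percentage points lower from compound 3 to compound 4 (within the scatter) and so gives the first direct reading at this position, a step that cannot be told apart from the usual variation between repeats. With the methyl in place, the ring on the thiocarbonyl carbon still counts: piperidin-1-yl in place of thiomorpholin-4-yl gives a number 12.5 percentage points lower from compound 2 to compound 4 (beyond the scatter) and piperidin-1-yl in place of morpholin-4-yl gives a number 53.5 percentage points higher from compound 1 to compound 4 (beyond the scatter) and this second step is far larger. No supporting measurement is available to explain any of these steps.

Going by these compounds, whether an amine or a methoxy group on that same aromatic carbon would move the growth inhibition remains open. Also open, on these data alone, is whether adding methyl would give a similar step in compounds carrying morpholin-4-yl or thiomorpholin-4-yl.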